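The compounds below may be only part of what the source reports. "The series", "measured", "known", "first", "only" and "open" are said of these compounds alone.

Measured in a functional assay on HepG2 cells (Homo sapiens) for antiproliferative activity, read by CCK-8 assay, with a stated time of 48 h; on this read-out higher numbers stand for weaker inhibition and lower numbers for stronger inhibition:
- Compound 1 `COc1ccc(/C=C\c2cc(OC)c(OC)c(OC)c2)cc1OCc1ccc(CO)cc1`: 2400 nM
- Compound 2 `COc1ccc(/C=C\c2cc(OC)c(OC)c(OC)c2)cc1OCc1ccc(CNCCNC(C)=O)cc1`: 6100 nM
- Compound 3 `COc1ccc(/C=C\c2cc(OC)c(OC)c(OC)c2)cc1OCc1ccc(CN2CC[C@@H](C(=O)O)C2)cc1`: 2300 nM

Compound 3 shares the low end of these values with compound 1, as a 1.0-fold lower number from compound 1 to compound 3 (0.02 log units; within the scatter) shows, while a 2.7-fold lower number from compound 2 to compound 3 (0.42 log units; beyond the scatter) sets it apart from compound 2.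

The next change, (2-((2-aminoethyl)carbamoyl)piperidin-1-yl in place of 3-carboxypyrrolidin-1-yl on a saturated chain carbon bound to an aromatic carbon), gives compound 4 `COc1ccc(/C=C\c2cc(OC)c(OC)c(OC)c2)cc1OCc1ccc(CN2CCCCC2C(=O)NCCN)cc1`. It falls at the same place as all three measured steps. Those steps stayed small: a 2.5-fold higher number from compound 1 to compound 2 (0.41 log units; beyond the scatter) was modest, and so was a 2.7-fold lower number from compound 2 to compound 3 (0.42 log units; beyond the scatter), while a 1.0-fold lower number from compound 1 to compound 3 (0.02 log units; within the scatter) showed no real change. Only a small shift in this assay is therefore expected, probably toward a higher number and perhaps none beyond the scatter. The expected change is a 1.4-fold higher number from compound 3 to compound 4 (0.14 log units; within the scatter). For compound 4 the estimate is 3200 nM, with an expected range of 1100 nM to 9000 nM.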

Compound 4, half-maximal inhibitory concentration: 4800 nM
Compound 4: middle estimate off by 1.5-fold (0.18 log units), on the low side; the range from low to high includes it.
By their numbers in this assay, from the lowest: compounds 3, 1, 4 and 2 (each within the scatter of the next, the first and the last beyond it).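

In this assay, 2-((2-aminoethyl)carbamoyl)piperidin-1-yl separates from 3-carboxypyrrolidin-1-yl, with a 2.1-fold higher number from compound 3 to compound 4 (0.32 log units; beyond the scatter), but not from the other two groups, with a 2.0-fold higher number from compound 1 to compound 4 (0.30 log units; within the scatter) and a 1.3-fold lower number from compound 2 to compound 4 (0.10 log units; within the scatter). At this saturated chain carbon, even this six-membered ring with its side chain produces no step larger than modest among the four compounds. Nothing measured here offers a cause for these small steps. As far as these compounds go, it remains open whether a carboxylic acid on the piperidine ring, in place of the 2-aminoethyl amide, would bring the number back toward compound 3, and whether a simple primary amine at this carbon would move it at all.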